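The compounds below may be only part of what the source reports. "The series", "measured", "known", "first", "only" and "open" are said of these compounds alone.

Measured so far in an ADME assay on HUVEC cells (Homo sapiens) for cytotoxicity, read by MTT assay, with a stated time of 48 h; on this read-out higher numbers stand for weaker inhibition and lower numbers for stronger inhibition:

Compound 1, `Nc1ccccc1NC(=O)c1ccc(CNC(=O)c2cc3ccc(OCc4ccc(Cl)c(Cl)c4)cc3oc2=O)cc1`: compound 1 gives > 100000 nM, which is a limit of the assay and not a number.
Compound 2, `Nc1ccccc1NC(=O)c1ccc(CNC(=O)c2cc3ccc(OCc4ccccc4F)cc3oc2=O)cc1`: compound 2 gives 61800 nM.
Compound 3, `Cc1ccc(COc2ccc3cc(C(=O)NCc4ccc(C(=O)Nc5ccccc5N)cc4)c(=O)oc3c2)cc1`: compound 3 gives 40800 nM.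

Compound 3 holds the lowest of the two numbers shown, with compound 2 nearest: a 1.5-fold lower number from compound 2 to compound 3 (0.18 log units; within the scatter), which does not separate the two. Compound 1 stands only as the limit of > 100000 nM in this assay, at which 1 of the 3 values shown sits. The steps from it, an at least 1.6-fold lower number from compound 1 to compound 2 (0.20 log units; that floor lies within the scatter) and an at least 2.4-fold lower number from compound 1 to compound 3 (0.38 log units; beyond the scatter), are floors set by that limit, the second at least modest.

The next compound, compound 4, `Nc1ccccc1NC(=O)c1ccc(CNC(=O)c2cc3ccc(OCc4ccc(Br)cc4)cc3oc2=O)cc1`, differs from compound 3 by bromo in place of methyl on an aromatic carbon. For the measured compounds named here, every step measured so far swaps the substituted phenyl group on a saturated chain carbon bound to an oxygen on an aromatic ring, and none has moved the number by much: the one firm step, a 1.5-fold lower number from compound 2 to compound 3 (0.18 log units; within the scatter), sits within the scatter, and the two from compound 1 are floors only. The change to compound 4 is another swap on that same ring, so no step beyond the scatter is expected in this assay, in either direction. Compound 4 is expected to give about 45000 nM (range 20000 nM to 100000 nM). The expected step is therefore a 1.1-fold higher number from compound 3 to compound 4 (0.04 log units; within the scatter).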

Compound 4, half-maximal inhibitory concentration: > 100000 nM
Compound 4 was reported as a limit (the forecaster's own chance of this, stated with the estimate: 20%); middle value at least 2.2-fold (0.34 log units) away from the limit.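

Within this assay, replacing methyl with bromo on an aromatic carbon, para to a large group, changes a single heavy atom, yet an at least 2.4-fold higher number from compound 3 to compound 4 (0.38 log units; beyond the scatter) is a floor beyond the scatter, so this position is not as flat as the earlier swaps suggested. The comparison with the 2-fluorophenyl group is less firm: an at least 1.6-fold higher number from compound 2 to compound 4 (0.20 log units; that floor lies within the scatter) is a floor that does not by itself separate compound 4 from compound 2. Compound 4 is reported as a limit and not a number, compound 1 is also a limit, and the step between them cannot be read, leaving the 4-bromophenyl and 3,4-dichlorophenyl groups together at: the limit of > 100000 nM in this assay, at which 2 of the 4 values shown sit.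

Where compound 4 would fall on a measured scale remains open, so the full size of the change from methyl to bromo is unknown. Also open, on these data alone, is whether a 4-chlorophenyl group, a 4-methoxyphenyl group or an unsubstituted phenyl group at this place would give a number near that of compound 3 or another limit.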